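Phenyl for hydrogen on the ether chain of an amine series

The source may hold more compounds than are shown below. What is called first, only, known or untested is meant among the compounds shown, and "the series" means these compounds.

Compound 1 `COCNc1n[n+]([O-])c2ccccc2[n+]1[O-]` gives 7800 nM in a functional assay on K562 cells (Homo sapiens) for cytotoxicity, read by MTT assay, with a stated time of 72 h; a lower number here means a stronger inhibitor, a higher number a weaker inhibitor. Compound 2 `[O-][n+]1nc(NCOCc2ccccc2)[n+]([O-])c2ccccc21` gives 16100 nM in this assay; compound 3 `CCOCNc1n[n+]([O-])c2ccccc2[n+]1[O-]` gives 15400 nM. The change phenyl in place of hydrogen on a saturated chain carbon bound to an oxygen on a saturated carbon made a step of a 2.1-fold higher number from compound 1 to compound 2 (0.31 log units; beyond the scatter), while methyl in place of hydrogen on a saturated chain carbon bound to an oxygen on a saturated carbon gave a 2.0-fold higher number from compound 1 to compound 3 (0.30 log units; within the scatter) and compound 2 against compound 3 reads a 1.0-fold lower number from compound 2 to compound 3 (0.02 log units; within the scatter). Compound 4 `CC(OCNc1n[n+]([O-])c2ccccc2[n+]1[O-])c1ccccc1` is not yet measured; it differs from compound 3 by phenyl in place of hydrogen on a saturated chain carbon bound to an oxygen on a saturated carbon and a saturated chain carbon. The cores of compound 1 and compound 3 differ by methyl in place of hydrogen on a saturated chain carbon bound to an oxygen on a saturated carbon. The place is not identical: in compound 3 the carbon is bound also to a saturated chain carbon, so this is the same kind of change, not the same. From compound 3 to compound 4 a step of about a 1.9-fold higher number from compound 3 to compound 4 (0.29 log units; within the scatter) is expected, resting on a 2.1-fold higher number from compound 1 to compound 2 (0.31 log units; beyond the scatter). The estimate for compound 4 is 30000 nM, within 12000 nM to 75000 nM.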

Compound 4, half-maximal inhibitory concentration: 8720 nM
For compound 4 the middle estimate is 3.4-fold (0.54 log units) above the measured one; the whole stated range lies above it.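

On the core of compound 3, phenyl in place of hydrogen gives a 1.8-fold lower number from compound 3 to compound 4 (0.25 log units; within the scatter), and on the core of compound 2, methyl in place of hydrogen gives a 1.8-fold lower number from compound 2 to compound 4 (0.27 log units; within the scatter); each step alone lies within the scatter and sets no direction. Read against the earlier step, the phenyl change does not carry over as a fixed increment in this assay: the same change on two cores in this assay, a 2.1-fold higher number (0.31 log units; beyond the scatter) from compound 1 to compound 2 and a 1.8-fold lower number (0.25 log units; within the scatter) from compound 3 to compound 4, 3.6-fold (0.56 log units) apart, beyond the scatter of two such steps. The methyl change does not carry over either, though these four compounds cannot show which core departs, or why: the same change on two cores in this assay, a 2.0-fold higher number (0.30 log units; within the scatter) from compound 1 to compound 3 and a 1.8-fold lower number (0.27 log units; within the scatter) from compound 2 to compound 4, 3.6-fold (0.56 log units) apart, beyond the scatter of two such steps.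

As far as these compounds go, whether this holds for other groups on the same carbon stays open. An ethyl, a cyclohexyl or a longer chain could test it.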